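A few compounds are considered here, and "the series" means these few. Any claim that something is new, unique, unknown or untested is made for them only; others in the source may bear on it.

Compound 1 `CCOc1cc(C(Nc2ccc3c(N)nccc3c2)C(=O)NS(=O)(=O)c2cccc(C(N)=O)c2)ccc1OC(C)C` is the reference point in an assay on isolated protein for inhibition of Trypsin (Homo sapiens); a higher number here means a weaker inhibitor, a lower number a stronger inhibitor. In this assay compound 1 gives > 5000 nM, which is a limit of the assay and not a number. Two close relatives sit at the same place. Compound 2 `CCOc1cc(C(Nc2ccc3c(N)nccc3c2)C(=O)NS(=O)(=O)c2cccc(S(N)(=O)=O)c2)ccc1OC(C)C`, which carries sulfamoyl in place of carbamoyl on an aromatic carbon, gives > 5000 nM in this assay, again a limit. Compound 3 `CCOc1cc(C(Nc2ccc3c(N)nccc3c2)C(=O)NS(=O)(=O)c2ccc(N)cc2)ccc1OC(C)C`, which carries 4-aminophenyl on the sulfonyl sulfur, gives > 5000 nM in this assay, also a limit. The measured steps among these three, a step that the two limits leave unreadable from compound 1 to compound 2, a step that the two limits leave unreadable from compound 1 to compound 3 and a step that the two limits leave unreadable from compound 2 to compound 3, cannot be sized because of the limit of > 5000 nM in this assay, at which 3 of the 3 values shown sit.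

Compound 4 `CCOc1cc(C(Nc2ccc3c(N)nccc3c2)C(=O)NS(=O)(=O)c2ccc(C)cc2)ccc1OC(C)C` differs from compound 1 by 4-methylphenyl in place of 3-carbamoylphenyl on a sulfonyl sulfur. Every measured step that touches the group on the sulfonyl sulfur is unreadable, so none of them yields a direction or a size for this change; what they do show is that three different groups at that position all leave the compound at the limit. On that basis compound 4 is expected to sit at or near the same limit, with an estimated value of 8000 nM in this assay, most likely between 2000 nM and 40000 nM. The step this estimate implies is a step that the limit leaves unreadable from compound 1 to compound 4, an expectation rather than a measurement.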

Compound 4, inhibition constant: 3040 nM
The estimate for compound 4 lay 2.6-fold (0.42 log units) above the measured number, and the stated range covers the measured number.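

In this assay, among the compounds shown here, compound 4 gives 3040 nM, the first number in this set that is not a limit, so a change in the group on the sulfonyl sulfur can give the series a readable number. The value gives an at least 1.6-fold lower number from compound 1 to compound 4 (0.21 log units; that floor lies within the scatter), an at least 1.6-fold lower number from compound 2 to compound 4 (0.21 log units; that floor lies within the scatter) and, for the single swap of amino to methyl, an at least 1.6-fold lower number from compound 3 to compound 4 (0.21 log units; that floor lies within the scatter); each of these is only a floor, and as printed that floor lies within the scatter, so the change is not shown to exceed it. The steps among the three earlier compounds remain unreadable, since those values are limits and not numbers: the limit of > 5000 nM in this assay, at which 3 of the 4 values shown sit.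

The compounds shown leave open how large the true steps to compound 4 are, and whether the methyl itself matters or only the loss of the carbamoyl, sulfamoyl and amino groups. They also leave open what a plain phenyl, a longer chain such as butyl, or a carboxylic acid in place of the methyl would give in this assay.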